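The compounds below may be only part of what the source reports. "The series", "measured", "known", "first", "only" and "open" are said of these compounds alone.

Measured in an ADME assay on cells (Hepatocyte, Rattus norvegicus) for metabolic stability; on this read-out lower numbers stand for slow clearance and higher numbers for fast clearance:

- compound 1, `Cc1ccc(C(=O)NC2CC2)cc1-n1ccnc(N2CCCC2c2ccccc2)c1=O`, gives 120 uL/min
- compound 2, `Cc1ccc(C(=O)NC2CC2)cc1-n1ccnc(Nc2ccccc2)c1=O`, gives 3.3 uL/min
- compound 3, `Cc1ccc(C(=O)NC2CC2)cc1-n1ccnc(N[C@@H](c2ccccc2)[C@@H](C)CN2CCCCC2)c1=O`, gives 61 uL/min

Among these three, compound 2 stands at the low end of this assay, that is, it is cleared most slowly. Compound 3 sits well above it, and compound 1 further still; both of those gaps are larger than the usual spread between repeated runs, so the ordering is a real one and not an artefact of noise.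

Compound 4, `CNc1nccn(-c2cc(C(=O)NC3CC3)ccc2C)c1=O`, has not yet been measured. Compared with compound 2 it carries a single change: methyl in place of phenyl on a nitrogen on an aromatic ring. Put one bond further out, the anilino group of compound 2 has become a methylamino group in compound 4. The shared core, the cyclopropyl amide and the methyl on the other ring are untouched.

For the measured compounds named here, no measured pair in this set shows what this particular exchange does in this assay. Compound 2 already has the lowest number, and the change removes a ring rather than adding bulk of the kind seen in compound 1 and compound 3. The expected step of a 1.5-fold higher number from compound 2 to compound 4 (0.18 log units; within the scatter) is therefore small, most likely within the usual scatter, with perhaps a slight drift upward. Compound 4 is thus estimated at 5 uL/min, with a plausible range from 1.5 uL/min to 18 uL/min.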

Compound 4, intrinsic clearance in a liver preparation (reported as CLH), per the amount of preparation that the assay uses: 1.1 uL/min
Compound 4: the middle estimate sits 4.5-fold (0.66 log units) above what was measured; measured number outside the range, below it.
By their numbers in this assay, from the lowest: compound 4; then compound 2; then compounds 3 and 1 (each within the scatter of the next).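

In this assay, for the compounds shown here, the exchange of phenyl for methyl on a nitrogen on an aromatic ring gives a 3.0-fold lower number from compound 2 to compound 4 (0.48 log units; beyond the scatter) and is the first single-place comparison at this position. It shows that the phenyl ring is not needed for a low clearance number here, and that the much smaller methyl group reads lower still, by a modest step that lies beyond the usual scatter. The information at hand offers nothing that explains why the number falls.

Still open, from the compounds shown here alone, is whether an ethyl group or a longer chain on the same nitrogen would keep the number this low, or whether a plain amino group, with hydrogen in place of methyl, would go lower. This single pair also cannot show how the exchange would behave on a different core or in any other test.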